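The compounds below may be only part of what the source reports. "The series", "measured", "known", "first", "only" and "open" are said of these compounds alone.

Measured compounds:
compound 1 `O=C(CN1CCN(S(=O)(=O)c2ccc(F)cc2)CC1)Nc1ccc(F)cc1` — 11600 nM
compound 2 `O=C(CN1CCN(S(=O)(=O)c2ccccc2F)CC1)Nc1ccc(F)cc1` — 13600 nM

Going by the values given here, in an in vitro assay on HEK ts201 cells for negative allosteric modulation of Neuronal acetylcholine receptor; alpha3/beta4 (Homo sapiens), read by fluorescence and calcium flux, with a stated time of 1.5 s (a higher number here means a weaker inhibitor, a lower number a stronger inhibitor), compound 2 gives 13600 nM, and its only neighbour is compound 1, the step of a 1.2-fold higher number from compound 1 to compound 2 (0.07 log units; within the scatter) lying within the scatter, so the two numbers stand together. Compound 3 `COC(=O)c1ccc(NC(=O)CN2CCN(S(=O)(=O)c3ccccc3F)CC2)cc1` differs from compound 2 by methoxycarbonyl in place of fluoro on an aromatic carbon. Among the compounds with values here, the one measured step concerns the aryl group on the sulfonyl sulfur, not the ring where compound 3 is changed, so no measured step bears on this change. Compound 3 is therefore expected close to compound 2, with an estimated step of a 1.1-fold lower number from compound 2 to compound 3 (0.05 log units; within the scatter). The estimate for compound 3 is 12000 nM, ranging from 4000 nM to 40000 nM.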

Compound 3, half-maximal inhibitory concentration: 11200 nM
Compound 3: the middle estimate sits 1.1-fold (0.03 log units) above what was measured; low and high end bracket the measured number.
By their numbers in this assay, from the lowest: compounds 3, 1 and 2 (each within the scatter of the next).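

Going by these compounds alone, the earlier compounds spoke only to the aryl group on the sulfonyl sulfur, whereas compound 3 gives the first reading at this other aromatic carbon, para to a large group. In this assay, the exchange of 4-fluorophenyl for 4-(methoxycarbonyl)phenyl gives a 1.2-fold lower number from compound 2 to compound 3 (0.08 log units; within the scatter), so this larger group with its two hydrogen-bond acceptors leaves the number level with that of fluoro. No evidence is available that accounts for this result. On these data alone, whether a carboxylic acid, an amine or a longer chain on this carbon would move the number beyond the scatter remains open.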